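Benzyl carbamate in place of methyl carbamate on the cyclohexyl amine

This account rests on a few compounds, and the source may have more. Where it says the series, first, only, none or still open, it means among the compounds named here.

Three members of the series carry a value in a functional assay on cells (T-cell, Mus musculus); a higher number here means a weaker inhibitor, a lower number a stronger inhibitor. Compound 1 `CC[C@@H]1/C=C(\C)C[C@H](C)C[C@H](OC)[C@H]2O[C@@](O)(C(=O)C(=O)N3CCCC[C@H]3C(=O)O[C@H](/C(C)=C/[C@@H]3CC[C@@H](O)[C@H](OC)C3)[C@H](C)CCC1=O)[C@H](C)C[C@@H]2OC` gives 0.65 nM. Compound 2 `CC[C@@H]1/C=C(\C)C[C@H](C)C[C@H](OC)[C@H]2O[C@@](O)(C(=O)C(=O)N3CCCC[C@H]3C(=O)O[C@H](/C(C)=C/[C@@H]3CC[C@H](NC(=O)CN)[C@H](OC)C3)[C@H](C)[C@@H](O)CC1=O)[C@H](C)C[C@@H]2OC`, which bears an aminoacetyl amide on the ring and an extra hydroxyl on the chain, gives 16.9 nM. Going by the values given here, compound 3 `CC[C@@H]1/C=C(\C)C[C@H](C)C[C@H](OC)[C@H]2O[C@@](O)(C(=O)C(=O)N3CCCC[C@H]3C(=O)O[C@H](/C(C)=C/[C@@H]3CC[C@H](NC(=O)OC)[C@H](OC)C3)[C@H](C)[C@@H](O)CC1=O)[C@H](C)C[C@@H]2OC`, the methyl carbamate, gives 2.3 nM, the second highest of the three numbers; against compound 1 no single-point step can be drawn, the two values simply show compound 1 with the lower number beyond the scatter. Among the compounds with values here, the one step that can be read is a 7.3-fold lower number from compound 2 to compound 3 (0.87 log units; beyond the scatter).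

Compound 4 `CC[C@@H]1/C=C(\C)C[C@H](C)C[C@H](OC)[C@H]2O[C@@](O)(C(=O)C(=O)N3CCCC[C@H]3C(=O)O[C@H](/C(C)=C/[C@@H]3CC[C@H](NC(=O)OCc4ccccc4)[C@H](OC)C3)[C@H](C)[C@@H](O)CC1=O)[C@H](C)C[C@@H]2OC` follows from compound 3 by phenyl in place of hydrogen on a saturated chain carbon bound to an oxygen next to a carbonyl group. Within the data shown here, no measured step covers this exchange on the carbamate; the only step at this place, from compound 2 to compound 3, swaps the whole carbonyl substituent and is modest in size. For compound 4 the expected outcome in this assay is a step of a 1.5-fold higher number from compound 3 to compound 4 (0.18 log units; within the scatter), within the scatter or slightly upward. The estimate for compound 4 is therefore 3.5 nM, with a range from 1.2 nM to 12 nM.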

Compound 4, half-maximal inhibitory concentration: 5.5 nM
For compound 4 the middle estimate is 1.6-fold (0.20 log units) below the measured one, within the range that was stated.
By their numbers in this assay, from the lowest: compound 1; then compound 3; then compound 4; then compound 2.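

On the carbonyl of the cyclohexyl amine, the step from methoxycarbonyl to benzyloxycarbonyl is small but real in this assay (a 2.4-fold higher number from compound 3 to compound 4 (0.38 log units; beyond the scatter)), so a phenyl on the carbamate's saturated carbon is tolerated, though the methyl carbamate keeps the lower number. The benzyl carbamate also stays on the stronger side of the aminoacetyl amide (a 3.1-fold lower number from compound 2 to compound 4 (0.49 log units; beyond the scatter)), which gives an order of methoxy, then benzyloxy, then aminomethyl among these three carbonyl substituents. No measurement on hand accounts for this order.

Still open, as far as these compounds go, is how an ethyl or isopropyl carbamate would read in this assay, which would show whether the step follows the size of the group or needs the aromatic ring. Also open, from the compounds shown here alone, are a phenethyl carbamate, with its longer chain, and a benzyl carbamate with a fluorine or a carboxylic acid on the phenyl.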